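The compounds below may be only part of what the source reports. "The series", "measured", "known", "first", "only" and "open" are said of these compounds alone.

Compound 1 `ClCc1ccccc1Cn1cnc2c(Cl)nc(Cl)nc21` and compound 2 `ClCc1cccc(Cn2cnc3c(Cl)nc(Cl)nc32)c1` have the same atoms joined differently; the difference between the two cores is not broken down here. In a functional assay on SF-539 cells (Homo sapiens) for cytotoxicity, read by sulforhodamine B assay, with a stated time of 48 h (on this read-out lower numbers stand for stronger inhibition of growth and higher numbers for weaker inhibition of growth), compound 1 gives 2880 nM, while compound 2 gives 14100 nM. Compound 3 `Nc1nc(Cl)c2ncn(Cc3ccccc3CCl)c2n1` differs from compound 1 by amino in place of chloro on an aromatic carbon, and in this assay compound 3 gives 38000 nM; the step is a 13-fold higher number from compound 1 to compound 3 (1.12 log units; beyond the scatter). Compound 4 `Nc1nc(Cl)c2ncn(Cc3cccc(CCl)c3)c2n1` is not yet measured; it differs from compound 2 by amino in place of chloro on an aromatic carbon, the same change at the same place as seen from compound 1 to compound 3. For compound 4 a step of about an 8.5-fold higher number from compound 2 to compound 4 (0.93 log units; beyond the scatter) is expected in this assay, resting on compound 2 at 14100 nM and on the size of a 13-fold higher number from compound 1 to compound 3 (1.12 log units; beyond the scatter). The estimate for compound 4 is 120000 nM, expected to fall between 40000 nM and 350000 nM.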

Compound 4, concentration for total growth inhibition: 20400 nM
The estimate for compound 4 lay 5.9-fold (0.77 log units) above the measured number; the measured number lies below the stated range.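

In this assay, amino in place of chloro on an aromatic carbon gives a 1.4-fold higher number from compound 2 to compound 4 (0.16 log units; within the scatter), so the size of the step seen on the core of compound 1 does not carry over to the core of compound 2: the same change on two cores in this assay, a 13-fold higher number (1.12 log units; beyond the scatter) from compound 1 to compound 3 and a 1.4-fold higher number (0.16 log units; within the scatter) from compound 2 to compound 4, 9.1-fold (0.96 log units) apart, beyond the scatter of two such steps. In this series, the size of this step therefore cannot be taken from one core and applied to the other. The two pairs do not show which difference between the cores sets the gap, or how a further core would behave.

Left open is how a methoxy group or a dimethylamino group at the same place would behave on each core. From the compounds shown here alone, whether the gap between the cores would persist with those groups also remains open.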